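A Fluoro Added to Compound 2

A few compounds are considered here, and "the series" means these few. Any claim that something is new, unique, unknown or untested is made for them only; others in the source may bear on it.

Measured in an ADME assay on Raji cells (Homo sapiens) for cytotoxicity, read by luminescence, with a stated time of 72 h (a lower number here means that less compound is needed, a higher number that more compound is needed for the effect), are these compounds:
Compound 1 `CCCCOc1cccc(-c2[nH]c3cc(OC)ccc3c(=O)c2C(=O)OCC)c1`: > 21500 nM
Compound 2 `CCOC(=O)c1c(-c2cccc(F)c2)[nH]c2cc(OC)ccc2c1=O`: > 21500 nM
Compound 3 `CCOC(=O)c1c(-c2cccc(NC(C)=O)c2)[nH]c2cc(OC)ccc2c1=O`: > 21500 nM

All three entries are limits and not numbers. Compound 2 gives > 21500 nM as a limit, so it holds no rank among the three. The evidence so far is the limit of > 21500 nM in this assay, at which 3 of the 3 values shown sit, and nothing more.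

Compound 4 `CCOC(=O)c1c(-c2cccc(F)c2)[nH]c2cc(OC)c(F)cc2c1=O` carries one structural change. The change from compound 2 to compound 4 is fluoro in place of hydrogen on an aromatic carbon and the rest of the structure stays the same.

The measured steps that bear on this change are a step that the two limits leave unreadable from compound 1 to compound 2 and a step that the two limits leave unreadable from compound 1 to compound 3 and a step that the two limits leave unreadable from compound 2 to compound 3 with no others available. None of them has a readable size, and none is a fluoro in place of hydrogen. No step beyond the scatter is therefore expected in this assay and no direction can be named. Compound 4 is expected to report a limit as well. This expectation rests on compound 2 at > 21500 nM as a limit. The estimate means a step that the limit leaves unreadable from compound 2 to compound 4 as an expected step. The estimated value for compound 4 is 30000 nM with an expected range from 12000 nM to 60000 nM as its upper end.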

Compound 4, half-maximal effective concentration: > 21500 nM
Compound 4: no number, only a limit; the forecaster's own chance of this, stated with the estimate: 85%; the middle value does not contradict the limit.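

In this assay compound 4 gives > 21500 nM, which is a limit and not a number. Going by these compounds alone, compound 2 gives > 21500 nM, likewise a limit, so no step between compound 2 and compound 4 can be read. The compounds shown leave open whether any of these structural changes alters the half-maximal effective concentration at all.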